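The source may hold more compounds than are shown below. What is called first, only, known or untested is meant among the compounds shown, and "the series" means these compounds.

In an ADME assay on MT4 cells (Homo sapiens) for cytotoxicity, read by MTT assay (on this read-out higher numbers stand for lower toxicity in this test and lower numbers for higher toxicity in this test), compound 3 `O=C1c2ccccc2C(=O)N1CCOC(=S)N(C(=O)c1ccc([N+](=O)[O-])cc1Cl)c1ccc(Cl)cc1` gives 19000 nM. Compound 1 `O=C1c2ccccc2C(=O)N1CCOC(=S)N(C(=O)c1ccccc1[N+](=O)[O-])c1ccc(Cl)cc1` gives 21000 nM, and the two lie within the scatter of each other, as a 1.1-fold lower number from compound 1 to compound 3 (0.04 log units; within the scatter) shows. Compound 2 `Cc1ccc(C(=O)N(C(=S)OCCN2C(=O)c3ccccc3C2=O)c2ccc(Cl)cc2)cc1` reads > 100000 nM, which is a limit of the assay. Compound 3 therefore stands at the low end of the three, level with compound 1.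

The change to compound 4 `Cc1cc(C(=O)N(C(=S)OCCN2C(=O)c3ccccc3C2=O)c2ccc(Cl)cc2)c(C)o1` is 2,5-dimethylfuran-3-yl in place of 2-chloro-4-nitrophenyl on a carbonyl carbon. No furan has been measured in this series, so the nearest guides are the two steps involving the 4-methylphenyl of compound 2: an at least 4.7-fold higher number from compound 1 to compound 2 (0.67 log units; beyond the scatter) and an at least 5.2-fold lower number from compound 2 to compound 3 (0.72 log units; beyond the scatter). Both lie beyond the scatter. Compound 4 resembles compound 2 in carrying methyl groups and no nitro group, so a modest rise in the number is expected in this assay, though with real uncertainty over its size. The estimated change is a 3.2-fold higher number from compound 3 to compound 4 (0.50 log units; beyond the scatter). For compound 4 the expected value is 60000 nM, with an estimated range from 22000 nM to 100000 nM.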

Compound 4, half-maximal cytotoxic concentration: 40000 nM
Beside the measured number, compound 4's estimate is 1.5-fold (0.18 log units) above it; the range from low to high includes it.
By their numbers in this assay, from the lowest: compounds 3, 1 and 4 (each within the scatter of the next, the first and the last beyond it). At a limit, above all of these: compound 2.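

In this assay, the 2,5-dimethylfuran-3-yl group shows that a five-membered aromatic ring on this carbonyl carbon can differ from the 2-chloro-4-nitrophenyl group, with a 2.1-fold higher number from compound 3 to compound 4 (0.32 log units; beyond the scatter), whereas the comparison with the 2-nitrophenyl group gives a 1.9-fold higher number from compound 1 to compound 4 (0.28 log units; within the scatter). The two groups without a nitro group also differ, with an at least 2.5-fold lower number from compound 2 to compound 4 (0.39 log units; beyond the scatter), so its absence alone does not set a single level at this position. Compound 2 is held at a limit rather than a number: the limit of > 100000 nM in this assay, at which 1 of the 4 values shown sits.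

The compounds shown do not separate the furan ring from its two methyl groups, which an unsubstituted furan-3-yl group would address. Going by these compounds, how an amine or a carboxylic acid on the ring, or a longer chain in place of the ring, would read at this carbonyl carbon remains open.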